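Swapping the ester tail: from pentyl to methyl(propyl)carbamoyl

A few compounds are considered here, and "the series" means these few. Any claim that something is new, unique, unknown or untested is made for them only; others in the source may bear on it.

Compound 1 `CCCCCCOC(=O)/C=C/c1ccc(NC(=O)C2(NC(=O)c3ccc4c(C5CCCC5)c(-c5ncc(Cl)cn5)n(C)c4c3)CCC2)cc1OCC` is the longer-lived of the two measured compounds in an ADME assay (liver) for pharmacokinetics, with Liver microsome (Rattus norvegicus) as the target, using microsomes; on this read-out higher numbers stand for a longer-lived compound and lower numbers for a shorter-lived compound: compound 1 gives 12.7 h, the highest of the two numbers. Among the compounds with values here, its only measured neighbour, compound 2 `CCOc1cc(NC(=O)C2(NC(=O)c3ccc4c(C5CCCC5)c(-c5ncc(Cl)cn5)n(C)c4c3)CCC2)ccc1/C=C/C(=O)OCC(N)=O`, gives 0.383 h in this assay, and the step of a 33-fold lower number from compound 1 to compound 2 (1.52 log units; beyond the scatter) is large, well beyond the usual scatter. That step is carbamoyl in place of pentyl on a saturated chain carbon bound to an oxygen next to a carbonyl group.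

Compound 3 `CCCN(C)C(=O)COC(=O)/C=C/c1ccc(NC(=O)C2(NC(=O)c3ccc4c(C5CCCC5)c(-c5ncc(Cl)cn5)n(C)c4c3)CCC2)cc1OCC` has not yet been measured. It differs from compound 1 by methyl(propyl)carbamoyl in place of pentyl on a saturated chain carbon bound to an oxygen next to a carbonyl group. Within the data shown here, this change sits at the same place as the one from compound 1 to compound 2, and again exchanges pentyl for a carbamoyl-type group, here carrying methyl and propyl. Among the measured compounds shown here, the one measured step that bears on it is a 33-fold lower number from compound 1 to compound 2 (1.52 log units; beyond the scatter), so a large drop in this assay is expected for compound 3 too, though it may not reach the full depth seen for compound 2.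

Compound 3 is therefore expected to give 0.8 h, within a range of 0.25 h to 2.5 h, in this assay.

This estimate means an expected step of a 16-fold lower number from compound 1 to compound 3 (1.20 log units; beyond the scatter).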

Compound 3, half-life: 0.317 h
Estimate against measurement, compound 3: 2.5-fold (0.40 log units) above; the measured number falls inside the stated range.
By their numbers in this assay, from the lowest: compounds 3 and 2 (each within the scatter of the next); then compound 1.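

In this assay, the drop first seen with the bare carbamoyl group also appears with a substituted one: methyl(propyl)carbamoyl in place of pentyl gives a 40-fold lower number from compound 1 to compound 3 (1.60 log units; beyond the scatter) for this change on a saturated chain carbon bound to an oxygen next to a carbonyl group. Replacing amino with methyl(propyl)amino on a carbonyl carbon gives a 1.2-fold lower number from compound 2 to compound 3 (0.08 log units; within the scatter) and so cannot be told apart from repeat-measurement noise, which means that across compound 2 and compound 3 the substituents on the amide nitrogen leave the result unresolved. The compounds shown therefore place both carbamoyl-type tails well away from the pentyl-bearing compound 1, but nothing measured here explains that gap.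

Going by these compounds, it remains open whether the amide carbonyl matters, or whether a tail with an ether oxygen in place of it, such as methoxyethyl, would sit nearer to compound 1 or nearer to compound 2 and compound 3. A ring-closed amide such as a morpholine amide, a tail ending in a carboxylic acid, and an alkyl chain longer than hexyl would each test how far this pattern extends.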